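The source may report more compounds than this note shows. Statements on the series, on what has been measured and on what is new or still open speak of the compounds shown alone.

Working notes on the series. In an assay on HepG2 cells for agonist activity at nuclear receptor subfamily 1 group I member 3 (Homo sapiens), read by a luciferase reporter, with a stated time of 23 h (a higher number here means that more compound is needed for the effect, a lower number that less compound is needed), compound 1 `CCc1nc2sccn2c1/C=N/OCc1ccc(Cl)c(Cl)c1` gives 2600 nM, compound 2 `COc1ccc(CO/N=C/c2c(-c3ccc4ccccc4c3)nc3occn23)cc1` gives 4400 nM, and compound 3 `N#Cc1ccc(-c2nc3sccn3c2/C=N/OCc2ccc(Cl)c(Cl)c2)cc1` gives 3400 nM. Compound 3 sits in the middle of the three numbers: compound 2 is its nearest neighbour, compound 1 the furthest, and both gaps are within the scatter, so no order among the three can be read from these numbers. Among the compounds with values here, the only single-point step measured so far, a 1.3-fold higher number from compound 1 to compound 3 (0.12 log units; within the scatter), swaps ethyl for 4-cyanophenyl at the same carbon that is varied next and does not move the number beyond the scatter.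

Compound 4 `Clc1ccc(CO/N=C/c2c(-c3cccc4ccccc34)nc3sccn23)cc1Cl` is the next member and is not yet measured. It differs from compound 3 by naphthalen-1-yl in place of 4-cyanophenyl on an aromatic carbon. The step from compound 1 to compound 3 is the one that bears on this change, since it alters the same carbon of the shared core, and it was flat. Compound 2 differs from compound 3 in more than one place, so its value can only be noted alongside, not read as a step. With nothing pointing in either direction, compound 4 is expected to give 3500 nM in this assay, within 1400 nM to 9000 nM. The expected step from compound 3 is therefore a 1.0-fold higher number from compound 3 to compound 4 (0.01 log units; within the scatter), none beyond the scatter.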

Compound 4, half-maximal effective concentration: 940 nM
For compound 4 the middle estimate is 3.7-fold (0.57 log units) above the measured one; the whole stated range lies above it.
By their numbers in this assay, from the lowest: compound 4; then compounds 1, 3 and 2 (each within the scatter of the next).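

In this assay, the aromatic carbon of the shared core looked flat from ethyl to 4-cyanophenyl (a 1.3-fold higher number from compound 1 to compound 3 (0.12 log units; within the scatter)), yet it responds to the group it carries: naphthalen-1-yl gives a 3.6-fold lower number from compound 3 to compound 4 (0.56 log units; beyond the scatter) and, measured against ethyl, a 2.8-fold lower number from compound 1 to compound 4 (0.44 log units; beyond the scatter). This position therefore does not tolerate every change without effect, and among the groups compared here on this core, only naphthalen-1-yl moves the number beyond the scatter, whereas the earlier ethyl and 4-cyanophenyl pair could not be told apart. No independent measurement bears on why this step occurs.

The change from compound 3 to compound 4 adds a second six-membered aromatic ring and removes the nitrile together, so the step cannot show which of the two matters, and unsubstituted phenyl on this carbon would separate them. Whether the number at this carbon follows size or ring count alone also stays open, since a longer chain such as butyl, or a phenyl bearing a carboxylic acid, stands outside the compounds shown.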